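Aryl methoxy pattern in the shared core: step to compound 4

The source may report more compounds than this note shows. Statements on the series, on what has been measured and on what is new or still open speak of the compounds shown alone.

Measured so far in a physicochemical assay, with a stated time of 60 min, tested at 60 ug/mL; on this read-out lower numbers stand for a weaker effect and higher numbers for a stronger effect at the one concentration tested:
compound 1 `CCOC(=O)[C@@H]1CC(=O)c2sccc2[C@H]1c1ccc(OC)cc1`: 24.8%
compound 2 `CCOC(=O)[C@@H]1CC(=O)c2sccc2[C@H]1c1ccc(OCC)cc1`: 27%
compound 3 `CCOC(=O)[C@@H]1CC(=O)c2sccc2[C@H]1c1ccccc1OC`: 22.8%

Compound 3 holds the lowest of the three numbers, but its gap to compound 1 and to compound 2 is within the scatter, so the three compounds are not separated in this assay.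

Compound 4 `CCOC(=O)[C@@H]1CC(=O)c2sccc2[C@H]1c1ccc(OC)cc1OC` differs from compound 3 by methoxy in place of hydrogen on an aromatic carbon.

Among the measured compounds shown here, the only single-place step measured is a number 2.2 percentage points higher from compound 1 to compound 2 (within the scatter), a change on a saturated chain carbon rather than on the aromatic ring; no measured step adds a methoxy group to the aromatic ring. For the measured compounds named here, it therefore gives no direct precedent, and no step beyond the scatter is expected. Compound 4 is estimated at 24%, range 14% to 34%, an expected step of a number 1.2 percentage points higher from compound 3 to compound 4 (within the scatter).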

Compound 4, a percentage reported as activity, at one concentration (the size of the read-out at that concentration, not a potency): 19.9%
Beside the measured number, compound 4's estimate is 4.1 percentage points above it; the range from low to high includes it.
By their numbers in this assay, from the lowest: compounds 4, 3, 1 and 2 (each within the scatter of the next).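

In this assay, methoxy in place of hydrogen on an aromatic carbon can now be read from two starting compounds (a number 2.9 percentage points lower from compound 3 to compound 4 (within the scatter)) and (a number 4.9 percentage points lower from compound 1 to compound 4 (within the scatter)). Placed para to the large group or meta to the existing methoxy group, this change gives no step beyond the scatter in either reading, so the added methoxy does not separate compound 4 from compound 1 or compound 3. No measurement available here bears on the cause of these small steps.

From the compounds shown here alone, whether an amine or a carboxylic acid on the aromatic ring would give a step beyond the scatter remains open. The same holds for a longer chain on the ring oxygen.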